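This account rests on a few compounds, and the source may have more. Where it says the series, first, only, none or still open, it means among the compounds named here.

Measured so far:
compound 1, `Cc1cc(C)cc(S(=O)(=O)c2c(C(=O)Nc3ccccc3O)[nH]c3ccc(Cl)cc23)c1` — in an ADME assay on MT4 cells (Homo sapiens) for cytotoxicity, read by MTT assay (a higher number here means that more compound is tolerated, a lower number that less compound is tolerated), compound 1 gives 19700 nM
compound 2, `Cc1cc(C)cc(S(=O)(=O)c2c(C(=O)NCc3ccccc3O)[nH]c3ccc(Cl)cc23)c1` — in this assay compound 2 gives 23800 nM

For the measured compounds named here, compound 2 sits at one end of these two numbers, but the only step available, a 1.2-fold higher number from compound 1 to compound 2 (0.08 log units; within the scatter), is within the scatter, so the two compounds cannot be told apart on this evidence.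

Compound 3, `Cc1cc(C)cc(S(=O)(=O)c2c(C(=O)Nc3ccc(CO)cc3)[nH]c3ccc(Cl)cc23)c1`, differs from compound 2 by 4-(hydroxymethyl)phenyl in place of 2-hydroxybenzyl on an amide-type nitrogen. Going by the values given here, the single measured step bears on this change: it also altered the group on the amide-type nitrogen, exchanging 2-hydroxyphenyl for 2-hydroxybenzyl, and it moved the number only by a 1.2-fold higher number from compound 1 to compound 2 (0.08 log units; within the scatter). On that basis the shared core appears to set the tolerated concentration, and another rearrangement of the same atoms on the same nitrogen is expected to give no step beyond the scatter, in either direction.

The step from compound 2 to compound 3 is therefore estimated as a 1.1-fold lower number from compound 2 to compound 3 (0.05 log units; within the scatter). Compound 3 is expected to give about 21000 nM in this assay, with a range of 10000 nM to 45000 nM.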

Compound 3, half-maximal cytotoxic concentration: 39600 nM
For compound 3 the middle estimate is 1.9-fold (0.28 log units) below the measured one; the measured number falls inside the stated range.
By their numbers in this assay, from the lowest: compounds 1, 2 and 3 (each within the scatter of the next).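

At this position, the amide-type nitrogen whose other neighbour is the carbonyl carbon, this assay now has a third group to compare. Putting 4-(hydroxymethyl)phenyl in place of 2-hydroxybenzyl gives (a 1.7-fold higher number from compound 2 to compound 3 (0.22 log units; within the scatter)), and putting it in place of 2-hydroxyphenyl gives (a 2.0-fold higher number from compound 1 to compound 3 (0.30 log units; within the scatter)). Both steps lie within the scatter, so even the widest gap among these three compounds does not separate them, and moving the hydroxyl-bearing part around on this nitrogen has shown no real effect on how much compound the cells tolerate; no measurement here offers an explanation for the small differences that are seen.

On these data alone, all three compounds carry an aromatic ring with a hydroxyl-bearing group on this nitrogen, so it remains open whether the tolerated concentration would hold with a different kind of group there, such as an amine, a carboxylic acid or a longer chain. The shared core is also identical in all three, which leaves open how much of the tolerated concentration depends on it.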